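Pendant aryl exchanges in a trimethoxyphenyl series

A few compounds are considered here, and "the series" means these few. Any claim that something is new, unique, unknown or untested is made for them only; others in the source may bear on it.

Among the compounds with values here, compound 3 `COc1cc(-n2cnc3ccc(-c4ccc(C(F)(F)F)cc4)cc32)cc(OC)c1OC` holds the second highest of the three numbers so far in a functional assay on MCF7 cells (Homo sapiens) for antiproliferative activity, read by MTT assay, with a stated time of 72 h; on this read-out higher numbers stand for weaker inhibition and lower numbers for stronger inhibition: compound 1 `COc1cc(-n2cnc3ccc(-c4cccc(N)c4)cc32)cc(OC)c1OC` gives 180 nM, compound 2 `COc1cc(-n2cnc3ccc(-c4cccc(F)c4)cc32)cc(OC)c1OC` gives 2350 nM, and compound 3 gives 760 nM. The steps seen were a 13-fold higher number from compound 1 to compound 2 (1.12 log units; beyond the scatter), a 4.2-fold higher number from compound 1 to compound 3 (0.63 log units; beyond the scatter) and a 3.1-fold lower number from compound 2 to compound 3 (0.49 log units; beyond the scatter). Compound 4 `COc1cc(-n2cnc3ccc(-c4cccc(C)c4C)cc32)cc(OC)c1OC` differs from compound 3 by 2,3-dimethylphenyl in place of 4-(trifluoromethyl)phenyl on an aromatic carbon. Within the data shown here, the only exchange between two phenyls carrying no donor, a 3.1-fold lower number from compound 2 to compound 3 (0.49 log units; beyond the scatter), was modest, while every aryl change so far moved the number beyond the scatter, so a modest step is expected for compound 4 as well, its direction uncertain. Compound 4 is therefore expected to give 1000 nM, between 300 nM and 3500 nM, a step of a 1.3-fold higher number from compound 3 to compound 4 (0.12 log units; within the scatter).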

Compound 4, half-maximal inhibitory concentration: 2150 nM
For compound 4 the middle estimate is 2.2-fold (0.33 log units) below the measured one; measured number inside the range.
By their numbers in this assay, from the lowest: compound 1; then compound 3; then compounds 4 and 2 (each within the scatter of the next).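

The 2,3-dimethylphenyl of compound 4 and the 3-fluorophenyl of compound 2 give numbers that sit level (a 1.1-fold lower number from compound 2 to compound 4 (0.04 log units; within the scatter)), whereas 4-(trifluoromethyl)phenyl stays clear of the new group (a 2.8-fold higher number from compound 3 to compound 4 (0.45 log units; beyond the scatter)). At this position, 3-aminophenyl keeps compound 1 apart from compound 4 as well (a 12-fold higher number from compound 1 to compound 4 (1.08 log units; beyond the scatter)), making compound 1 the strongest of the four. No supporting data bear on why these aryl groups differ. Still open, from the compounds shown here alone, is whether 4-aminophenyl would hold the low number of compound 1, and whether a hydroxyl or dimethylamino group could replace the amine.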